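Methoxy to methylpiperazine on two related cores

This account rests on a few compounds, and the source may have more. Where it says the series, first, only, none or still open, it means among the compounds named here.

Compound 1 `COc1ccc(-c2cc3[nH]nc(N)c3c(=O)[nH]2)cc1` and compound 2 `CN1CCN(c2ccc(-c3cc4[nH]nc(N)c4c(=O)[nH]3)cc2)CC1` share one core, while compound 3 `COc1ccc(-c2cc3nn(-c4ccccc4)c(N)c3c(=O)[nH]2)cc1` and compound 4 `CN1CCN(c2ccc(-c3cc4nn(-c5ccccc5)c(N)c4c(=O)[nH]3)cc2)CC1` carry a second core; the difference between the two cores is not broken down here. In an assay on isolated protein for inhibition of RAC-beta serine/threonine-protein kinase (Homo sapiens), read by mobility shift assay, tested at 30 uM (a higher number here means more inhibition at the concentration tested (going by the name of the read-out), a lower number less inhibition), compound 1 gives 11%, and compound 2 gives 6%. The change 4-methylpiperazin-1-yl in place of methoxy on an aromatic carbon thus made a step of a number 5 percentage points lower from compound 1 to compound 2 (within the scatter). In this assay compound 3 gives 0%. Compound 4 carries the same change on the core of compound 3, (4-methylpiperazin-1-yl in place of methoxy on an aromatic carbon). A step of about the same small size is expected, a number 2 percentage points higher from compound 3 to compound 4 (within the scatter), because compound 3 gives 0% and the matching step a number 5 percentage points lower from compound 1 to compound 2 (within the scatter) lay within the scatter. Compound 4 is therefore estimated to give 2%, expected to fall between -8% and 12%.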

Compound 4, a percentage reported as inhibition, at one concentration (the size of the read-out at that concentration, not a potency): 10%
Estimate against measurement, compound 4: 8 percentage points below, within the range that was stated.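

On the second core, the same change gave a number 10 percentage points higher from compound 3 to compound 4 (within the scatter) in this assay, so neither step alone lies beyond the scatter. Set side by side, however, the two steps differ, and the change did not carry over from one core to the other as a single fixed step: the same change on two cores in this assay, a number 5 percentage points lower (within the scatter) from compound 1 to compound 2 and a number 10 percentage points higher (within the scatter) from compound 3 to compound 4, 15 percentage points apart, beyond the scatter of two such steps. This does not show why the steps differ, and two cores say nothing about how the change would behave on any other core.

The compounds shown leave open how other groups on this aromatic carbon, such as a morpholine, a primary amine or a carboxylic acid, would behave on either core. On these data alone, whether any such group would give a step beyond the scatter also remains open.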